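One Group Swap on a Sulfonyl Sulfur

The compounds below may be only part of what the source reports. "The series", "measured", "known", "first", "only" and "open" are said of these compounds alone.

Compound 1 `COc1ccc([C@H]2CC(=O)N(c3cccc(S(C)(=O)=O)c3)C2)cc1OC1CCCC1` gives > 10000 nM (a limit of the assay)
Compound 2 `COc1ccc(OC)c(S(=O)(=O)Nc2cccc(N3C[C@@H](c4ccc(OC)c(OC5CCCC5)c4)CC3=O)c2)c1` gives 7590 nM

Among the measured compounds shown here, in a functional assay on HEK293 cells (Homo sapiens) for cytotoxicity (a higher number here means that more compound is tolerated, a lower number that less compound is tolerated), compound 2 gives 7590 nM as the only actual number so far. Compound 1 gives > 10000 nM here, and that is a limit of the assay and not a number. For the measured compounds named here, with only one real number, compound 2 cannot yet be ranked against anything.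

The next compound to be tested is compound 3 `COc1ccc([C@H]2CC(=O)N(c3cccc(NS(=O)(=O)c4ccccc4Cl)c3)C2)cc1OC1CCCC1`, which is still unmeasured. Going by the values given here, it keeps the rest of compound 2 and carries 2-chlorophenyl in place of 2,5-dimethoxyphenyl on a sulfonyl sulfur as its single change.

Among the compounds with values here, no pair of measured compounds shows what a change at this place does in this assay so the only anchor is compound 2 with 7590 nM as its value. No shift beyond the usual scatter is expected. The expected step of a 1.1-fold lower number from compound 2 to compound 3 (0.04 log units; within the scatter) is small and has no firm direction. For compound 3 the estimate is 7000 nM with an expected range from 3000 nM to 15000 nM as the likely span.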

Compound 3, half-maximal cytotoxic concentration: > 10000 nM
Compound 3 was reported as a limit (the forecaster's own chance of this, stated with the estimate: 35%); middle value at least 1.4-fold (0.15 log units) away from the limit.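

In this assay, the swap on the sulfonyl sulfur gives a measured pair of compounds that differ in one place: an at least 1.3-fold higher number from compound 2 to compound 3 (0.11 log units; that floor lies within the scatter). Compound 3 sits at a limit of the assay and not at a number, so this step is only a floor, and its real size stays hidden because readings stop at that limit: the limit of > 10000 nM in this assay, at which 2 of the 3 values shown sit. Among the compounds shown here, replacing 2,5-dimethoxyphenyl with 2-chlorophenyl therefore shows no sign that less compound is tolerated, and it shows no shift that can be separated from the usual scatter, while the step between compound 1 and compound 3 cannot be read because both are limits.

The compounds shown leave open how far beyond the limit compound 3 lies, and so whether compound 2 and compound 3 truly differ at all. They also leave open what this position would tolerate with a different kind of group on the sulfonyl sulfur, such as a dimethylamino group or a phenyl ring carrying a carboxylic acid.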